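The source may hold more compounds than are shown below. What is called first, only, known or untested is meant among the compounds shown, and "the series" means these compounds.

Measured so far in a functional assay on RS4-11 cells (Homo sapiens) for inhibition, read by CCK-8 assay, with a stated time of 72 h; a lower number here means a stronger inhibitor, a higher number a weaker inhibitor:

Compound 1, `COc1ccc(C2=C(CN3CCN(c4ccc(C(=O)NS(=O)(=O)c5ccc(NCC6CCOCC6)c([N+](=O)[O-])c5)c(Oc5cnc6[nH]ccc6c5)c4)CC3)CCC(C)(C)C2)cc1`, gives 12 nM.
Compound 2, `CC1(C)CCC(CN2CCN(c3ccc(C(=O)NS(=O)(=O)c4ccc(NCC5CCOCC5)c([N+](=O)[O-])c4)c(Oc4cnc5[nH]ccc5c4)c3)CC2)=C(c2ccccc2C(F)(F)F)C1`, gives 18 nM.
Compound 3, `CN(C)CCCNc1ccc(S(=O)(=O)NC(=O)c2ccc(N3CCN(CC4=C(c5ccc(C(F)(F)F)cc5)CC(C)(C)CC4)CC3)cc2Oc2cnc3[nH]ccc3c2)cc1[N+](=O)[O-]`, gives 3.9 nM.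

The one single-point step among these is a 1.5-fold higher number from compound 1 to compound 2 (0.18 log units; within the scatter), and it concerns the aryl group on the double-bonded ring carbon, not the sulfonamide side. Compound 3 stands lowest of the three numbers; compound 1 is nearer to it and compound 2 is furthest, and both gaps lie beyond the scatter.

Compound 4, `CC1(C)CCC(CN2CCN(c3ccc(C(=O)NS(=O)(=O)c4ccc(OCC5CCSCC5)c([N+](=O)[O-])c4)c(Oc4cnc5[nH]ccc5c4)c3)CC2)=C(c2ccc(C(F)(F)F)cc2)C1`, is not yet measured. It differs from compound 3 in one place: a group of 8 heavy atoms (6 carbon, 1 oxygen, 1 sulfur; one six-membered non-aromatic ring with 1 hetero atom) in place of a group of 7 heavy atoms (5 carbon, 2 nitrogen; no ring), on an aromatic carbon. Going by the values given here, no measured step bears directly on this change. Compounds 1 and 2 carry a different group from compound 3 at this position, but they also differ from compound 3 on the aryl ring, so their values show only that both stand higher than compound 3, not what this particular exchange does. Without a step at this position, the estimate leans on the values of compounds 1 and 2 as a guide to what a group other than (3-(dimethylamino)propyl)amino might bring here.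

Compound 4 is therefore expected to show a modest rise, a 2.6-fold higher number from compound 3 to compound 4 (0.41 log units; beyond the scatter), and its estimated value in this assay is 10 nM, with a range of 3 nM to 35 nM.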

Compound 4, half-maximal inhibitory concentration: 15 nM
Compound 4: middle estimate off by 1.5-fold (0.18 log units), on the low side; the measured number falls inside the stated range.
By their numbers in this assay, from the lowest: compound 3; then compounds 1, 4 and 2 (each within the scatter of the next).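

Going by these compounds alone, the exchange at this position can now be read directly for the first time: in this assay, putting the sulfur-containing ring group in place of (3-(dimethylamino)propyl)amino gives a 3.8-fold higher number from compound 3 to compound 4 (0.59 log units; beyond the scatter). The position, on an aromatic carbon ortho to a nitro group and para to a large group, is therefore not indifferent to what it carries, at least for this pair with the core of compound 3 otherwise unchanged. Within the data shown here, the single step nevertheless changes several things at once, since the entering group brings a six-membered non-aromatic ring and a sulfur and oxygen, loses both nitrogens, and has 0 hydrogen-bond donors where the leaving group has 1, so the step cannot be assigned to any one of these features, and no measurement offered here explains it.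

The compounds shown leave open whether a shorter chain such as (2-(dimethylamino)ethyl)amino, a morpholine ring or a carboxylic acid at this position would stand nearer to compound 3 or to compound 4. They also leave open whether the same exchange would give a similar step with a 4-methoxyphenyl group on the double-bonded ring carbon.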